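The compounds below may be only part of what the source reports. "The series", "measured", "known", "first", "only" and "open" are said of these compounds alone.

Compound 1, `CC1=C(N2CC2)C(=O)C(CCCOC(N)=O)=C(N2CC2)C1=O`: 5.48
Compound 2, `CCOC(COC(N)=O)C1=C(N2CC2)C(=O)C(C)=C(N2CC2)C1=O`: 4.62
Compound 3, `CCC1=C(N2CC2)C(=O)C(C(COC(N)=O)OC)=C(N2CC2)C1=O`: 4.92

These three compounds were measured in a functional assay on L1210 cells (Mus musculus), with a stated time of 1 days; a lower number here means a less potent compound, a higher number a more potent compound, by a factor of ten per unit of this negative logarithm. Compound 2 stands at the low end of the set: its number lies below that of compound 1 by a gap beyond the scatter, while compound 3 gives a number within the scatter of compound 2, so the two cannot be told apart. Compound 4, `COCCOC(COC(N)=O)C1=C(N2CC2)C(=O)C(C)=C(N2CC2)C1=O`, has not yet been measured. It differs from compound 2 in one place: methoxy in place of hydrogen on a saturated chain carbon, two bonds along the chain from an oxygen on a saturated carbon. Within the data shown here, no measured pair in the set shows this change, so there is no direct step to draw on. The shared core is left as it is, and only the chain grows, so a step of no more than the scatter is expected in either direction in this assay, estimated as a number 0.08 log units higher from compound 2 to compound 4 (within the scatter). Compound 4 is therefore expected to give about 4.7, with a range from 4.2 to 5.3.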

Compound 4, logarithm of the reciprocal of the active concentration, log(1/C): 4.96
The estimate for compound 4 lay 0.26 log units below the measured number, and the stated range covers the measured number.
By their numbers in this assay, from the lowest: compounds 2, 3 and 4 (each within the scatter of the next, the first and the last beyond it); then compound 1.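

In this assay, among these compounds, the change from ethoxy to 2-methoxyethoxy gives a number 0.34 log units higher from compound 2 to compound 4 (beyond the scatter), the first step in the set that isolates a single place. It shows that this chain can grow by a methoxy group with no loss in this assay, and with a modest gain. No evidence is available to explain this step. From the compounds shown here alone, whether a longer chain or an amine in place of the methoxy would go further remains open. So does whether one step at this position holds for other changes to the chain.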